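A few compounds are considered here, and "the series" means these few. Any claim that something is new, unique, unknown or untested is made for them only; others in the source may bear on it.

Compound 1 `CC(C)=CCOc1cc(=O)n(CCCO)c2c1CC(CC=C(C)C)C(C)(C)C2`: in a functional assay on PANC-1 cells (Homo sapiens) for inhibition, read by MTT assay, with a stated time of 24 h, tested at 10 uM (a higher number here means more inhibition at the concentration tested (going by the name of the read-out), a lower number less inhibition), compound 1 gives 7.5%
Compound 2 `CC(C)=CCC1Cc2c(OCCCNC(=O)c3cccs3)cc(=O)n(CCCO)c2CC1(C)C`: compound 2 gives 5.6%
Compound 3 `COc1cccc(NC(=O)Oc2cc(=O)n(CCCO)c3c2CC(CC=C(C)C)C(C)(C)C3)c1`: compound 3 gives 0%

All three numbers are low and lie within the scatter of one another: a number 1.9 percentage points lower from compound 1 to compound 2 (within the scatter), a number 7.5 percentage points lower from compound 1 to compound 3 (within the scatter) and a number 5.6 percentage points lower from compound 2 to compound 3 (within the scatter), so compound 3 cannot be set apart from compound 1 or compound 2. Compound 4 `CC(C)=CCC1Cc2c(OC(=O)Nc3ccc(F)cc3)cc(=O)n(CCCO)c2CC1(C)C` carries 4-fluorophenyl in place of 3-methoxyphenyl on an amide-type nitrogen. For the measured compounds named here, no measured step alters the group on this amide-type nitrogen; the two steps that touch the same oxygen, a number 7.5 percentage points lower from compound 1 to compound 3 (within the scatter) and a number 5.6 percentage points lower from compound 2 to compound 3 (within the scatter), replace the whole substituent and still stay within the scatter. A shift beyond the scatter is therefore not expected. The step from compound 3 to compound 4 is estimated as a number 3 percentage points higher from compound 3 to compound 4 (within the scatter). Compound 4 is expected at 3%, with a range from 0% to 12%.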

Compound 4, a percentage reported as inhibition, at one concentration (the size of the read-out at that concentration, not a potency): 0%
Compound 4: the middle estimate sits 3 percentage points above what was measured, within the range that was stated.
By their numbers in this assay, from the lowest: compounds 3, 4, 2 and 1 (each within the scatter of the next).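

In this assay, for the compounds shown here, the step 4-fluorophenyl in place of 3-methoxyphenyl on the amide-type nitrogen gives no change at the digits printed from compound 3 to compound 4 (within the scatter) and is the first direct change at this position. The other two steps, with (4-fluorophenyl)carbamoyl on the oxygen, give a number 5.6 percentage points lower from compound 2 to compound 4 (within the scatter) and a number 7.5 percentage points lower from compound 1 to compound 4 (within the scatter), so none of the four compounds can be set apart. No supporting data offer an explanation for this result. Still open, going by these compounds, is whether an amine or a carboxylic acid on the phenyl ring would move the number in this assay beyond the scatter.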